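A few compounds are considered here, and "the series" means these few. Any claim that something is new, unique, unknown or untested is made for them only; others in the source may bear on it.

Compound 1 `N#C/N=C(\NCCCc1ccccc1)NCCCc1c[nH]cn1` is the point of departure here. In an in vitro functional assay on Sf9 cells for antagonist activity at histamine H2 receptor (Homo sapiens) (a higher number here means a more potent compound, by a factor of ten per unit of this negative logarithm, a lower number a less potent compound), compound 1 gives 5.25, the higher of the two numbers obtained. Compound 2 `N#C/N=C(\NCCCCc1ccccc1)NCCCc1c[nH]cn1` gives 5.03 in this assay, and the step of a number 0.22 log units lower from compound 1 to compound 2 (within the scatter) lies within the scatter. Compound 3 `N#C/N=C(/NCCCc1c[nH]cn1)NCCCC1CCCCC1` returns only a limit of the assay, < 5; < 5 (2 entries), in two entries.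

Compound 4 `N#C/N=C(/NCCCCCc1c[nH]cn1)NCCCc1ccccc1` differs from compound 1 on the side carrying the imidazole ring: 2-(1H-imidazol-4-yl)ethyl in place of 1H-imidazol-4-yl on a saturated chain carbon, three bonds along the chain from an amine nitrogen. Among the measured compounds shown here, no measured step alters that part of the molecule. For the measured compounds named here, the only measured step, a number 0.22 log units lower from compound 1 to compound 2 (within the scatter), lengthened the chain on the phenyl side and stayed within the scatter, so it serves only as a loose analogy. Since the chain that carries the imidazole ring has not been varied among the measured compounds, a loss of potency of moderate size is expected rather than supported by a direct comparison. Compound 4 is therefore estimated at 4.7, with a range from 4.2 to 5.3. The expected step of a number 0.55 log units lower from compound 1 to compound 4 (beyond the scatter) means a somewhat weaker compound, with a real chance that only a limit is reported.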

Compound 4, negative logarithm of the antagonist equilibrium constant: 5.28
For compound 4 the middle estimate is 0.58 log units below the measured one, and the stated range covers the measured number.
By their numbers in this assay, from the lowest: compounds 2, 1 and 4 (each within the scatter of the next).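

Swapping 1H-imidazol-4-yl for 2-(1H-imidazol-4-yl)ethyl, on a saturated chain carbon, three bonds along the chain from an amine nitrogen, gives a number 0.03 log units higher from compound 1 to compound 4 (within the scatter) in this assay. Among the compounds shown here, this is the first measured change on the side carrying the imidazole ring, and it shows that this chain can take 3-(1H-imidazol-4-yl)propyl in place of (1H-imidazol-4-yl)methyl with no difference beyond the scatter. No available evidence accounts for this result.

The compounds shown leave open whether an even longer chain, or an amine or a thiazole ring in place of the imidazole ring, would give a similar number. They also leave open how the longer imidazole-side chain of compound 4 would behave alongside the longer phenyl-side chain of compound 2.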